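The source may hold more compounds than are shown below. What is called first, only, known or untested is meant among the compounds shown, and "the series" means these compounds.

Working notes on the series

Compound 1 `CC1=C(CCC(=O)OCCCCOc2no[n+]([O-])c2S(=O)(=O)c2ccccc2)C(=O)c2c(O)cccc2C1=O` and compound 3 `CC1=C(CCC(=O)OCCCOc2no[n+]([O-])c2S(=O)(=O)c2ccccc2)C(=O)c2c(O)cccc2C1=O` carry the same nitroquinone-bearing ester side chain on a common core; how the two cores differ is not broken down here. In a functional assay on MDA-MB-231 cells (Homo sapiens) for inhibition, read by MTT assay, with a stated time of 72 h, tested at 10 uM (on this read-out higher numbers stand for more inhibition of growth at the one concentration tested and lower numbers for less inhibition of growth), compound 1 gives 97.6% and compound 3 gives 96.8%, two values that lie within the scatter of each other, both close to full inhibition at the single concentration tested.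

Compound 2 `CC1=C(C(C)CC(=O)OCCCCOc2no[n+]([O-])c2S(=O)(=O)c2ccccc2)C(=O)c2c(O)cccc2C1=O` differs from compound 1 in one place only, (methyl in place of hydrogen on a saturated chain carbon bound to a double-bonded ring carbon and a saturated chain carbon). In this assay compound 2 gives 92.7%, and the measured step is a number 4.9 percentage points lower from compound 1 to compound 2 (within the scatter), so within this series the added methyl has left the read-out essentially unchanged.

Compound 4 `CC1=C(C(C)CC(=O)OCCCOc2no[n+]([O-])c2S(=O)(=O)c2ccccc2)C(=O)c2c(O)cccc2C1=O` has not yet been measured. It stands to compound 3 as compound 2 stands to compound 1: the change is methyl in place of hydrogen on a saturated chain carbon bound to a double-bonded ring carbon and a saturated chain carbon, at a place described in the same words as before, so it is the same change, occurring twice among these four compounds.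

Going by the values given here, for compound 4 the step expected in this assay is a number 4.8 percentage points lower from compound 3 to compound 4 (within the scatter), placed beside the one measured instance a number 4.9 percentage points lower from compound 1 to compound 2 (within the scatter), on which the expectation rests, together with compound 3 giving 96.8% as the starting point. Because compound 1 already gives 97.6%, a value close to full inhibition, the expectation for compound 4 is not placed higher than the values seen so far. Compound 4 is therefore estimated at 92%, with a range from 85% to 98%.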

Compound 4, percent growth inhibition at one concentration: 95.3%
Compound 4: middle estimate off by 3.3 percentage points, on the low side; measured number inside the range.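

The methyl in place of hydrogen on a saturated chain carbon gives, in this assay, a number 1.5 percentage points lower from compound 3 to compound 4 (within the scatter), and the step on the second core does not differ from the one on the first: the same change on two cores in this assay, a number 4.9 percentage points lower (within the scatter) from compound 1 to compound 2 and a number 1.5 percentage points lower (within the scatter) from compound 3 to compound 4, 3.4 percentage points apart, within the scatter of two such steps.

Across these two cores the change therefore carries over as a step that stays within the scatter each time, with nothing in the four compounds going against this. It does not show that the change is without effect in general: there are only two instances, every number sits close to full inhibition at the one concentration tested, and a single-concentration read-out this near its ceiling may leave little room for a difference to appear, so a shift in potency could go unseen and nothing follows for any other core.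

The compounds shown leave open whether another group at the same place, such as an ethyl, a hydroxyl or an amine, would also leave the read-out within the scatter. They also leave open how the methyl change would behave with a carboxylic acid in place of the ester, or with a longer chain.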